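Weak binders: from a ring amide to an open-chain amine

The source may hold more compounds than are shown below. What is called first, only, known or untested is meant among the compounds shown, and "the series" means these compounds.

Compound 2 (`CC(C)(C)c1ccc(C(=O)N2CCC3(CC2)C(=O)N(CC(=O)N2CCCCC2CO)CN3c2ccccc2)cc1`) is one of two molecules so far tested in an assay on HEK293 cells for displacement of a labelled ligand from NPC1-like intracellular cholesterol transporter 1 (Homo sapiens); a higher number here means a weaker inhibitor, a lower number a stronger inhibitor. In this assay compound 2 gives 11800 nM, and compound 1 (`CC1CCCN(C(=O)CN2CN(c3ccccc3)C3(CCN(C(=O)c4ccc(C(C)(C)C)cc4)CC3)C2=O)C1`) gives 12000 nM. The two numbers sit together: the step of a 1.0-fold lower number from compound 1 to compound 2 (0.01 log units; within the scatter) shows that exchanging one group on the carbonyl carbon for another left the result where it was, so compound 2 stands level with compound 1 rather than apart from it.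

Compound 3 (`CC(C)(C)c1ccc(C(=O)N2CCC3(CC2)C(=O)N(CC(=O)NCCCCN)CN3c2ccccc2)cc1`) continues this theme at the same carbonyl carbon: (4-aminobutyl)amino in place of 2-(hydroxymethyl)piperidin-1-yl on a carbonyl carbon. Among the measured compounds shown here, no measured step covers this exact exchange; the only step available, from compound 1 to compound 2, was within the scatter and also swapped a group at this carbonyl carbon. On that basis the expected change for compound 3 in this assay is none beyond the scatter, which means a step of a 1.2-fold lower number from compound 2 to compound 3 (0.07 log units; within the scatter) is estimated. The estimate for compound 3 in this assay is therefore 10000 nM, with an expected range from 3000 nM to 40000 nM.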

Compound 3, half-maximal inhibitory concentration: 14500 nM
Compound 3: the middle estimate sits 1.5-fold (0.16 log units) below what was measured; the measured number falls inside the stated range.
By their numbers in this assay, from the lowest: compounds 2, 1 and 3 (each within the scatter of the next).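

Compound 3 has no ring at this carbonyl carbon, yet in this assay the result is a 1.2-fold higher number from compound 2 to compound 3 (0.09 log units; within the scatter) and a 1.2-fold higher number from compound 1 to compound 3 (0.08 log units; within the scatter). The earlier pair only exchanged one substituted piperidin-1-yl group for another, whereas here a six-membered non-aromatic ring gives way to an open (4-aminobutyl)amino chain, and the count of hydrogen-bond donors in the exchanged group goes from 1 to 2, with no shift beyond the scatter. Among these three compounds, then, neither the ring nor the extra donor separates one number from another, and no measurement at hand bears on what lies behind this level result.

All three values lie within the scatter of one another, so these compounds do not show whether any group at this carbonyl carbon can move the number beyond the scatter. On these data alone, it remains open how the number would respond to a carboxylic acid in place of the amino group of the chain, to a longer chain carrying the same amine, or to an aromatic ring such as phenyl on the same carbonyl carbon.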